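The compounds below may be only part of what the source reports. "The series", "measured", "known", "first", "only" and "open" are said of these compounds alone.

Compound 1 `N#Cc1c(Nc2cccc([N+](=O)[O-])c2)nc(SCc2cn(Cc3ccccc3Cl)nn2)nc1-c1ccccc1` — in a functional assay on ECa-109 cells (Homo sapiens) for inhibition, read by MTT assay, with a stated time of 72 h (on this read-out lower numbers stand for stronger inhibition and higher numbers for weaker inhibition), compound 1 gives > 64000 nM, which is a limit of the assay rather than a number.
Compound 2 `N#Cc1c(Nc2ccccc2F)nc(SCc2cn(Cc3ccccc3Cl)nn2)nc1-c1ccccc1` — in this assay compound 2 gives 23000 nM.
Compound 3 `Cc1ccccc1Nc1nc(SCc2cn(Cc3ccccc3Cl)nn2)nc(-c2ccccc2)c1C#N` — in this assay compound 3 gives 9740 nM.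

All three share one core and differ only in the group carried on the nitrogen on an aromatic ring. The value of compound 1 is a limit (the limit of > 64000 nM in this assay, at which 1 of the 3 values shown sits), so its steps are limits too: an at least 2.7-fold lower number from compound 1 to compound 2 (0.44 log units; beyond the scatter) and an at least 6.5-fold lower number from compound 1 to compound 3 (0.81 log units; beyond the scatter). Between the two numbers, a 2.4-fold lower number from compound 2 to compound 3 (0.37 log units; beyond the scatter). Compound 3 therefore holds the lowest number shown, with compound 2 nearest to it.

Compound 4 `Cc1ccc(Cn2cc(CSc3nc(Nc4ccccc4C)c(C#N)c(-c4ccccc4)n3)nn2)cc1` changes a different part of the molecule: 4-methylphenyl in place of 2-chlorophenyl on a saturated chain carbon bound to an aromatic nitrogen. Among the compounds with values here, none of the measured steps touches this position; each of them alters the group on the nitrogen on an aromatic ring while the 2-chlorobenzyl on the triazole stays fixed. Within the data shown here, there is thus no measured step that bears directly on the change from compound 3 to compound 4, and an expectation can rest only on compound 3 itself. For compound 4 a step of a 1.0-fold higher number from compound 3 to compound 4 (0.01 log units; within the scatter) is expected, that is, nothing beyond the scatter. The estimate for compound 4 in this assay is 10000 nM, with a range from 3000 nM to 35000 nM.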

Compound 4, half-maximal inhibitory concentration: > 64000 nM
Compound 4: no number, only a limit; the forecaster's own chance of this, stated with the estimate: 10%; at least 6.4-fold (0.80 log units) between middle value and limit.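

Within the data shown here, until compound 4, every measured step altered the group on the nitrogen on an aromatic ring while the 2-chlorophenyl stayed fixed, so the earlier compounds said nothing about the position on a saturated chain carbon bound to an aromatic nitrogen. Compound 4 shows that this position is not indifferent in this assay: with the rest of compound 3 unchanged, 4-methylphenyl in place of 2-chlorophenyl gives an at least 6.5-fold higher number from compound 3 to compound 4 (0.81 log units; beyond the scatter), a change at least as large as the one seen when methyl replaced fluoro on the aromatic carbon, a 2.4-fold lower number from compound 2 to compound 3 (0.37 log units; beyond the scatter). The value of compound 4 is a limit and not a number, so the step gives only a minimum and its full size stays unknown: the limit of > 64000 nM in this assay, at which 2 of the 4 values shown sit.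

The change from 2-chlorophenyl to 4-methylphenyl alters both the substituent and the place it occupies on the ring, and the compounds shown cannot separate the two, which a 2-methylphenyl or a 4-chlorophenyl at this position would do. They also leave open how this position would respond to an unsubstituted phenyl, or to a longer chain ending in an amine or a carboxylic acid.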